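The source may report more compounds than this note shows. Statements on the series, on what has been measured and on what is new or still open speak of the compounds shown alone.

Of the compounds shown here, three of one shared core have been measured so far. Compound 1 `O=C(Nc1cccc(-n2cc(-c3ccncc3)c(-c3ccc(Cl)c(O)c3)n2)c1)Nc1cccc(C(F)(F)F)c1` gives 2240 nM in a functional assay on A498 cells (Homo sapiens) for inhibition, read by sulforhodamine B assay, with a stated time of 48 h; on this read-out lower numbers stand for stronger inhibition and higher numbers for weaker inhibition. Compound 2 `COc1cc(-c2nn(-c3cccc(NC(=O)Nc4cc(C(F)(F)F)cc(C(F)(F)F)c4)c3)cc2-c2ccncc2)ccc1Cl` gives 610 nM in this assay, and compound 3 `COc1cc(-c2nn(-c3cccc(NC(=O)c4cccc(C(F)(F)F)c4)c3)cc2-c2ccncc2)ccc1Cl` gives 690 nM in this assay. Compound 3 thus stands second highest of the three numbers: its nearest neighbour is compound 2, whose number is within the scatter of repeated measurements, while compound 1 lies furthest away, beyond the scatter. For the measured compounds named here, compound 2 and compound 3 differ in more than one place, so no single step between measured compounds is available for guidance.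

Compound 4 `COc1cc(-c2nn(-c3cccc(NC(=O)Nc4ccc(Cl)c(Cl)c4)c3)cc2-c2ccncc2)ccc1Cl` has not yet been measured. It differs from compound 3 in one place: (3,4-dichlorophenyl)amino in place of 3-(trifluoromethyl)phenyl on a carbonyl carbon. Compound 2 already carries a carbamoyl group of this kind and sits close to compound 3, so for the step from compound 3 to compound 4 a change of about a 1.3-fold lower number from compound 3 to compound 4 (0.10 log units; within the scatter) in this assay is expected, which is no more than the scatter. Compound 4 is therefore estimated at 550 nM, with a likely range from 250 nM to 1200 nM.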

Compound 4, half-maximal inhibitory concentration: 1140 nM
Estimate against measurement, compound 4: 2.1-fold (0.32 log units) below; the measured number falls inside the stated range.
By their numbers in this assay, from the lowest: compounds 2, 3, 4 and 1 (each within the scatter of the next, the first and the last beyond it).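

In this assay, putting (3,4-dichlorophenyl)amino in place of 3-(trifluoromethyl)phenyl on the carbonyl carbon gives a 1.7-fold higher number from compound 3 to compound 4 (0.22 log units; within the scatter). For the compounds shown here, this is the first direct comparison at this position, and it does not separate the two groups, even though the entering group carries a hydrogen-bond donor and the leaving group carries none. Nothing measured here accounts for the size of this step.

From the compounds shown here alone, the step changes the link to the ring and the groups on that ring together, so the share of each remains unknown. Also open, going by these compounds, is whether a different group on this carbonyl carbon, such as a piperidine ring or a simple methyl, would move the number beyond the scatter.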